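Swapping an aromatic arm for a hexyl chain

A few compounds are considered here, and "the series" means these few. Any claim that something is new, unique, unknown or untested is made for them only; others in the source may bear on it.

Compound 1 `CCCCCOCNc1n[n+]([O-])c2ccccc2[n+]1[O-]` gives 39500 nM in a functional assay on KB cells (Homo sapiens) for cytotoxicity, read by MTT assay, with a stated time of 72 h; a higher number here means a weaker inhibitor, a lower number a stronger inhibitor.
Compound 2 `[O-][n+]1nc(NCOCc2ccc(C(F)(F)F)cc2)[n+]([O-])c2ccccc21` gives 19800 nM in this assay.
Compound 3 `COc1ccc(COCNc2n[n+]([O-])c3ccccc3[n+]2[O-])cc1` gives 14200 nM in this assay.

Compound 3 carries the lowest of the three numbers. Its gap to compound 2 is within the scatter, so the two cannot be told apart, while its gap to compound 1, a 2.8-fold lower number from compound 1 to compound 3 (0.44 log units; beyond the scatter), lies beyond the scatter. Compound 4 `CCCCCCCOCNc1n[n+]([O-])c2ccccc2[n+]1[O-]` differs from compound 3 in one place: hexyl in place of 4-methoxyphenyl on a saturated chain carbon bound to an oxygen on a saturated carbon. Among the compounds with values here, the step that bears on this is the one from compound 1 to compound 3, where an aromatic group replaced a chain and the number fell by a 2.8-fold lower number from compound 1 to compound 3 (0.44 log units; beyond the scatter). Within the data shown here, compound 4 reverses that kind of change, replacing the aromatic group with a chain, though a longer one than in compound 1, and no measured pair shows what chain length alone does. The number for compound 4 is therefore expected to rise, a 2.3-fold higher number from compound 3 to compound 4 (0.35 log units; beyond the scatter), back toward the level of compound 1. The estimate for compound 4 in this assay is 32000 nM, with a range from 13000 nM to 80000 nM.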

Compound 4, half-maximal inhibitory concentration: 14000 nM
Compound 4: the middle estimate sits 2.3-fold (0.36 log units) above what was measured; low and high end bracket the measured number.
By their numbers in this assay, from the lowest: compounds 4, 3, 2 and 1 (each within the scatter of the next, the first and the last beyond it).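

At this position an aromatic ring turns out not to be required in this assay: with hexyl in place of 4-methoxyphenyl there is a 1.0-fold lower number from compound 3 to compound 4 (0.01 log units; within the scatter) and the two compounds cannot be told apart. Chain length does count, since ethyl in place of hydrogen at the far end of the chain gives a 2.8-fold lower number from compound 1 to compound 4 (0.45 log units; beyond the scatter) and so a longer chain without any ring reaches the level of compound 3, which means the earlier step from compound 1 to compound 3 need not be credited to the ring itself. No supporting measurement is available to say why these changes behave this way.

From the compounds shown here alone, whether a still longer chain, such as decyl, would lower the number further remains open. So does the outcome of placing an amine or a carboxylic acid at the end of the hexyl chain.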